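Replacing 2-(4-methylpiperazin-1-yl)ethyl with 3-(dimethylamino)propyl

This account rests on a few compounds, and the source may have more. Where it says the series, first, only, none or still open, it means among the compounds named here.

Compound 1 `N#Cc1nc2c(-c3nc4ccccc4[nH]3)c(N)n(CCN3CCCC3)c2nc1C#N` gives > 50000 nM in a functional assay on Raji cells (Homo sapiens) for antiproliferative activity, read by MTT assay, with a stated time of 48 h (on this read-out higher numbers stand for weaker inhibition and lower numbers for stronger inhibition), and this is a limit of the assay, not a number. Compound 2 `CN1CCN(CCn2c(N)c(-c3nc4ccccc4[nH]3)c3nc(C#N)c(C#N)nc32)CC1` gives > 50000 nM, which is also only a limit. The picture so far is therefore (the limit of > 50000 nM in this assay, at which 2 of the 2 values shown sit), so compound 2 has no exact position on the scale.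

Compound 3 `CN(C)CCCn1c(N)c(-c2nc3ccccc3[nH]2)c2nc(C#N)c(C#N)nc21` has not yet been measured. It differs from compound 2 in one place: (dimethylamino)methyl in place of 4-methylpiperazin-1-yl on a saturated chain carbon, two bonds along the chain from an aromatic nitrogen. Here, (dimethylamino)methyl stands in place of 4-methylpiperazin-1-yl on a saturated chain carbon, two bonds along the chain from an aromatic nitrogen. The same difference can be read as 2-(4-methylpiperazin-1-yl)ethyl changing to 3-(dimethylamino)propyl.

Among the measured compounds shown here, the one measured step that bears on this change, at the same chain carbon, is a step that the two limits leave unreadable from compound 1 to compound 2. It gives no size to carry over, so the expectation rests on both measured compounds sitting at the same limit. No step beyond the scatter is expected in this assay, and the estimated step is a number no higher from compound 2 to compound 3 (the limit leaves the size open). Compound 3 is expected at 50000 nM, with an estimated range of 20000 nM to 100000 nM.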

Compound 3, half-maximal inhibitory concentration: 1230 nM
For compound 3 the middle estimate is 41-fold (1.61 log units) above the measured one, and the stated range ends above it.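

In this assay, among the compounds shown here, compound 3 gives the first exact number in this set, 1230 nM, so the chain on this aromatic nitrogen of the shared core is a place where a single change can turn a compound with no measurable value into one with a real one. The change is large whichever compound serves as the starting point: there is an at least 40-fold lower number from compound 2 to compound 3 (1.60 log units; beyond the scatter), and likewise an at least 40-fold lower number from compound 1 to compound 3 (1.60 log units; beyond the scatter). Compound 1 and compound 2 each give only a limit of the assay, not a number, so the step between them cannot be read: the limit of > 50000 nM in this assay, at which 2 of the 3 values shown sit.

Going to 3-(dimethylamino)propyl alters two things at once, the length of the chain and the form of the amine, which changes from a ring to an open dimethylamino group, so the compounds shown cannot tell which of the two matters. A 3-(4-methylpiperazin-1-yl)propyl group would keep the ring on the longer chain and a 2-(dimethylamino)ethyl group would keep the open amine on the shorter one, and those two would separate the effects, while a 4-(dimethylamino)butyl group would show whether lengthening the chain further changes the result.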